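The source may report more compounds than this note shows. Statements on the series, on what has been measured and on what is new or still open speak of the compounds shown alone.

Measured compounds:
- compound 1, `CCn1c(SCC(=O)c2ccccc2)nnc1-c1ccc(OC)cc1`: 67%
- compound 2, `CCn1c(SCC(=O)c2ccccc2)nnc1-c1cc(OC)c(OC)c(OC)c1`: 49%

Both compounds were tested in a functional assay on the whole organism (strain albino) for inhibition, with Rattus norvegicus as the target, read by paw edema, with a stated time of 3 h, at a dose of 0.28 mmol/kg by the oral route; a higher number here means more inhibition at the dose given (going by the name of the read-out), a lower number less inhibition. Compound 1, `CCn1c(SCC(=O)c2ccccc2)nnc1-c1ccc(OC)cc1`, gives 67% in this assay. Compound 2, `CCn1c(SCC(=O)c2ccccc2)nnc1-c1cc(OC)c(OC)c(OC)c1`, gives 49%, the lower of the two numbers, and its distance from compound 1 lies beyond the usual scatter of repeated measurements. Within the data shown here, no single-change step between measured compounds is available, so the gap between compound 1 and compound 2 can only be stated as what the two values show.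

Compound 3, `CCn1c(SCC(=O)c2ccccc2)nnc1-c1ccc(OC)c(OC)c1`, is the next compound to be measured in this assay. It differs from compound 2 in one place: hydrogen in place of methoxy on an aromatic carbon. The change moves compound 3 partway from compound 2 toward compound 1 in the number of methoxy groups on that ring, so a small rise from compound 2 to compound 3 is expected, most likely one that stays within the scatter rather than clearly beyond it. On this basis compound 3 is estimated to give 57% in this assay, with a range from 45% to 69%. The expected step from compound 2 to compound 3 is a number 8 percentage points higher from compound 2 to compound 3 (within the scatter).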

Compound 3, a percentage reported as inhibition, in the whole organism at one dose (the size of the read-out at that dose, not a potency): 61%
Compound 3: middle estimate off by 4 percentage points, on the low side; measured number inside the range.
By their numbers in this assay, from the lowest: compound 2; then compounds 3 and 1 (each within the scatter of the next).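

In this assay, the methoxy group ortho to a methoxy group and meta to a large group proves to matter when it is exchanged for hydrogen: the step is a number 12 percentage points higher from compound 2 to compound 3 (beyond the scatter), a change on one aromatic carbon that can be told from the scatter. The other single change, methoxy in place of hydrogen on an aromatic carbon, gives a number 6 percentage points lower from compound 1 to compound 3 (within the scatter), so this added methoxy group cannot be told from the scatter, and the two methoxy groups on the ring of these compounds thus do not count alike in this read-out. Nothing measured here explains either step.

The compounds shown leave open how a hydroxyl group, a chlorine atom or an amine on the aromatic carbon of the first step would read against hydrogen and methoxy. They also leave open whether that step would hold with a longer chain in place of the ethyl group on the shared core, and since each number comes from one dose at one time, they give no potency.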